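A few compounds are considered here, and "the series" means these few. Any claim that something is new, unique, unknown or untested is made for them only; others in the source may bear on it.

Measured so far:
compound 1 `Cc1ccc(O)c(/C=N\NC(=O)c2oc3cccc(O)c3c2C)c1`, in a functional assay on PC-3 cells (Homo sapiens) for inhibition (a lower number here means a stronger inhibitor, a higher number a weaker inhibitor), giving 7350 nM
compound 2 `Cc1c(C(=O)N/N=C\c2cc([N+](=O)[O-])ccc2O)oc2cccc(O)c12`, in this assay giving 17100 nM

Compound 1 stands lowest of these two numbers; its nearest neighbour is compound 2, reached by a 2.3-fold higher number from compound 1 to compound 2 (0.37 log units; beyond the scatter), a modest step that changes a substituent on the same ring. Compound 3 `Cc1c(C(=O)N/N=C\c2ccc(Br)cc2O)oc2cccc(O)c12` differs from compound 1 by 4-bromo-2-hydroxyphenyl in place of 2-hydroxy-5-methylphenyl on a carbon with a double bond to nitrogen. Among the compounds with values here, only that one step bears on this change, and it was modest, so a step of similar size, or none beyond the scatter, is expected in this assay, with a 1.2-fold higher number from compound 1 to compound 3 (0.09 log units; within the scatter) as the expected outcome. Compound 3 is therefore estimated at 9000 nM, within a range from 3000 nM to 27000 nM.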

Compound 3, half-maximal inhibitory concentration: 2050 nM
For compound 3 the middle estimate is 4.4-fold (0.64 log units) above the measured one; the measured number lies below the stated range.
By their numbers in this assay, from the lowest: compound 3; then compound 1; then compound 2.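

With a 3.6-fold lower number from compound 1 to compound 3 (0.55 log units; beyond the scatter) in this assay the change on the carbon with a double bond to nitrogen moves the number downward. The earlier replacement, with a 2.3-fold higher number from compound 1 to compound 2 (0.37 log units; beyond the scatter) as its step, had moved it upward, so this part of compound 1 can shift the number either way. No measurement shown accounts for this difference. Going by these compounds, it remains open whether the bromine or its different place on the ring matters, and whether a chlorine or an amine on that ring would follow compound 3.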